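Adding ring bulk to the chloro compound: clearance outlook

This account rests on a few compounds, and the source may have more. Where it says the series, first, only, none or still open, it means among the compounds named here.

Measured in an ADME assay on microsomes from liver (Homo sapiens) for metabolic stability; on this read-out higher numbers stand for fast clearance and lower numbers for slow clearance:
- Compound 1 `CC(=O)N[C@@H]1CCC[C@H](C(=O)Nc2cc(-c3cnc(C)n3C(C)C)ccn2)C1`: 3.6 mL.min-1.g-1
- Compound 2 `CC(=O)N[C@@H]1CCC[C@H](C(=O)Nc2cc(-c3cnc4n3CCC4)c(Cl)cn2)C1`: 9.7 mL.min-1.g-1
- Compound 3 `CC(=O)N[C@@H]1CCC[C@H](C(=O)Nc2cc(-c3cnn4c3CC(C)(C)C4)c(C#N)cn2)C1`: 26 mL.min-1.g-1

Compound 2, at 9.7 mL.min-1.g-1, is the middle value of the three, with compound 3 higher and compound 1 lower, both gaps beyond the scatter. Compound 4 `CC(=O)N[C@@H]1CCC[C@H](C(=O)Nc2cc(-c3cnc4n3CC(C)(C)C4)c(Cl)cn2)C1` differs from compound 2 by a group of 10 heavy atoms (8 carbon, 2 nitrogen; one five-membered non-aromatic ring with 1 hetero atom, one five-membered aromatic ring with 2 hetero atoms) in place of a group of 8 heavy atoms (6 carbon, 2 nitrogen; one five-membered non-aromatic ring with 1 hetero atom, one five-membered aromatic ring with 2 hetero atoms), on an aromatic carbon, opposite the ring nitrogen and ortho to a chloro group. Among the measured compounds shown here, no measured pair isolates this change. Compound 3 has the highest value, 26 mL.min-1.g-1, and also carries a group of 10 heavy atoms, but it differs elsewhere too, so it offers only weak support. A modest rise is expected, a 1.5-fold higher number from compound 2 to compound 4 (0.19 log units; within the scatter), possibly within the scatter. For compound 4 the estimated value is 15 mL.min-1.g-1, with an expected range of 8 mL.min-1.g-1 to 30 mL.min-1.g-1.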

Compound 4, intrinsic clearance in microsomes: 63 mL.min-1.g-1
The estimate for compound 4 lay 4.2-fold (0.62 log units) below the measured number; measured number outside the range, above it.
By their numbers in this assay, from the lowest: compound 1; then compound 2; then compound 3; then compound 4.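

In this assay, among the compounds shown here, the group of 10 heavy atoms in place of the group of 8 heavy atoms, on an aromatic carbon ortho to a chloro group, gives a 6.5-fold higher number from compound 2 to compound 4 (0.81 log units; beyond the scatter), the first change at this position isolated. With the chloro group and the rest of the core held constant, this enlargement of the group alone is enough to move clearance beyond the scatter. Nothing available explains the rise.

On these data alone, whether the step carries over to compounds without the chloro group remains open. So does whether a fluoro or hydroxyl group on the five-membered non-aromatic ring would leave clearance close to that of compound 2.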